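A few compounds are considered here, and "the series" means these few. Any claim that something is new, unique, unknown or untested is made for them only; others in the source may bear on it.

Measured so far:

Compound 1 `CNc1nc(/C=C/c2cc(OC)c(OC)c(OC)c2)nc2ccsc12` sits at a limit of the assay in a functional assay on L02 cells (Homo sapiens) for inhibition, read by Griess assay, with stated times of 1 h and 24 h (on this read-out higher numbers stand for weaker inhibition and lower numbers for stronger inhibition), where compound 1 gives > 1000000 nM.
Compound 2 `CCN1CCN(c2nc(/C=C/c3cc(OC)c(OC)c(OC)c3)nc3ccsc23)CC1` also sits at a limit, where compound 2 gives > 1000000 nM.
Compound 3 `COc1cc(/C=C/c2nc(NCc3ccc(C)cc3)c3sccc3n2)cc(OC)c1OC` likewise sits at a limit, where compound 3 gives > 1000000 nM.

Compound 3 therefore stands at the same limit as the other two, and nothing separates the three on the numbers shown; none can be called stronger or weaker. The three measured steps are all unreadable for the same reason: a step that the two limits leave unreadable from compound 1 to compound 2, a step that the two limits leave unreadable from compound 1 to compound 3 and a step that the two limits leave unreadable from compound 2 to compound 3 each run between two limits, so their size cannot be read. Within the data shown here, the one piece of evidence is the limit of > 1000000 nM in this assay, at which 3 of the 3 values shown sit.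

Compound 4 `COc1ccc(CNc2nc(/C=C/c3cc(OC)c(OC)c(OC)c3)nc3ccsc23)cc1` differs from compound 3 by methoxy in place of methyl on an aromatic carbon. Among the measured compounds shown here, the measured steps say nothing about the size of this change, only that the whole shared core has so far stayed at the limit. Compound 4 is expected to remain there too, estimated at 2000000 nM with a range from 300000 nM to 10000000 nM. The expected step is a step that the limit leaves unreadable from compound 3 to compound 4, meaning no change readable beyond the limit.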

Compound 4, half-maximal inhibitory concentration: > 1000000 nM
Compound 4: no number, only a limit; the forecaster's own chance of this, stated with the estimate: 85%; the middle value lies beyond the limit too.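

Among these compounds, compound 4 also gives a limit rather than a number, so no step among compound 1, compound 2, compound 3 and compound 4 can be read: the limit of > 1000000 nM in this assay, at which 4 of the 4 values shown sit. The compounds shown leave open how far these four truly differ in this assay, and whether any change to the shared core would give a readable value.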